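A Dichlorophenyl Urea Follows Three Analogues at the Limit

The source may hold more compounds than are shown below. What is called first, only, known or untested is meant among the compounds shown, and "the series" means these compounds.

Compound 3 `COc1cc(-c2nn(-c3cccc(NC(=O)Nc4ccc(Cl)c(C(F)(F)F)c4)c3)cc2-c2ccncc2)ccc1Cl` is a urea whose outer aryl carries a chloro group and a trifluoromethyl group. In a functional assay on K562 cells (Homo sapiens) for inhibition, read by sulforhodamine B assay, with a stated time of 48 h (a lower number here means a stronger inhibitor of growth, a higher number a weaker inhibitor of growth), compound 3 gives only a limit, > 32500 nM. Its two relatives are the amide compound 1 `COc1cc(-c2nn(-c3cccc(NC(=O)c4cccc(C(F)(F)F)c4)c3)cc2-c2ccncc2)ccc1Cl` and the urea compound 2 `COc1cc(-c2nn(-c3cccc(NC(=O)Nc4cccc(C(F)(F)F)c4)c3)cc2-c2ccncc2)ccc1Cl`. In this assay compound 1 stops at the limit > 50000 nM. In this assay compound 2 likewise stops at the limit > 50000 nM. The steps among the three cannot be sized because two values sit at the limit of > 50000 nM in this assay, at which 2 of the 3 values shown sit, and one at the limit of > 32500 nM in this assay, at which 1 of the 3 values shown sits: a step that the two limits leave unreadable from compound 1 to compound 2, a step that the two limits leave unreadable from compound 1 to compound 3 and a step that the two limits leave unreadable from compound 2 to compound 3. Compound 3 thus stands level with its relatives as far as the numbers allow one to say, all three beyond the reach of the measurement.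

Compound 4 `COc1cc(-c2nn(-c3cccc(NC(=O)Nc4ccc(Cl)c(Cl)c4)c3)cc2-c2ccncc2)ccc1Cl` differs from compound 3 in one place: chloro in place of trifluoromethyl on an aromatic carbon. For the measured compounds named here, none of the measured steps offers a readable size to carry over, and none shows any analogue of this series producing a number. The expectation for compound 4 is therefore that this assay again reports only a limit, with an estimated step that the limit leaves unreadable from compound 3 to compound 4. The estimate for compound 4 is 50000 nM, between 15000 nM and 200000 nM.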

Compound 4, concentration for total growth inhibition: > 50000 nM
Compound 4: a limit, no number; the forecaster's own chance of this, stated with the estimate: 80%; the middle value lies on the limit itself.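

In this assay compound 4 gives only a limit, > 50000 nM. Its steps to compound 1, compound 2 and compound 3 cannot be read. The compounds shown leave open whether any of these aryl ureas or the amide would give a true number in this assay, and how their outer aryl groups would then rank.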